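Methylation of the core ring nitrogen in compound 1

This account rests on a few compounds, and the source may have more. Where it says the series, first, only, none or still open, it means among the compounds named here.

Compound 1 `O=C(Nc1ccc(Oc2ccnc3[nH]ccc23)c(F)c1)c1nn(-c2ccc(Cl)cc2)ccc1=O` is the parent of this small set. In a functional assay on MCF7 cells (Homo sapiens) for cytotoxicity, read by MTT assay, with a stated time of 72 h (a higher number here means a weaker inhibitor, a lower number a stronger inhibitor), compound 1 gives > 60000 nM, which is a limit of the assay rather than a number, so compound 1 stands at the weak end of what has been measured (the limit of > 60000 nM in this assay, at which 1 of the 3 values shown sits). Compound 2 `O=C(Nc1ccc(Oc2ccnc3[nH]ccc23)c(F)c1)c1nn(-c2ccc(Cl)c(F)c2)ccc1=O` gives 11600 nM in this assay, and compound 3 `O=C(Nc1ccc(Oc2ccnc3[nH]ccc23)c(F)c1)c1nn(-c2ccc(Cl)c(C(F)(F)F)c2)ccc1=O` gives 11600 nM. The measured steps all concern the chlorophenyl end: an at least 5.1-fold lower number from compound 1 to compound 2 (0.71 log units; beyond the scatter) and an at least 5.1-fold lower number from compound 1 to compound 3 (0.71 log units; beyond the scatter) each move away from the limit, while no change at the digits printed from compound 2 to compound 3 (within the scatter) shows no difference beyond the scatter.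

Compound 4 `Cn1ccc2c(Oc3ccc(NC(=O)c4nn(-c5ccc(Cl)cc5)ccc4=O)cc3F)ccnc21` differs from compound 1 in a different part of the molecule: methyl in place of hydrogen on an aromatic nitrogen. Within the data shown here, none of the measured steps touches this nitrogen, so no direct precedent exists for the size or direction of its effect. With nothing to point the other way, compound 4 is expected to remain close to compound 1, which means a step that the limit leaves unreadable from compound 1 to compound 4 in this assay, with a good chance that only a limit is again reported. The estimate for compound 4 is therefore 70000 nM, within a range from 25000 nM to 250000 nM.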

Compound 4, half-maximal inhibitory concentration: > 60000 nM
Compound 4: a limit, no number; the forecaster's own chance of this, stated with the estimate: 70%; the middle value is on the limit's open side.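

In this assay compound 4 gives > 60000 nM, a limit of the assay and not a number. Compound 1 also stands at a limit, so no step between compound 1 and compound 4 can be read: the limit of > 60000 nM in this assay, at which 2 of the 4 values shown sit.

The compounds shown leave open what methyl in place of hydrogen on an aromatic nitrogen does in a compound whose value is a number rather than a limit.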